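Quinolone carboxamide series: cytotoxicity on Vero cells

The source may hold more compounds than are shown below. What is called first, only, known or untested is meant among the compounds shown, and "the series" means these compounds.

Of the compounds shown here, three have been measured in an ADME assay on Vero cells (Chlorocebus sabaeus) for cytotoxicity, read by MTT assay, with a stated time of 16 h; a higher number here means that more compound is tolerated, a lower number that less compound is tolerated. Compound 1 `CCn1cc(C(=O)Nc2ccc(F)c(Cl)c2)c(=O)c2ccc(C(F)(F)F)cc21` gives > 20000 nM, which is a limit of the assay and not a number. Compound 2 `NC(=O)C1CCN(c2cc3c(cc2F)c(=O)c(C(=O)NCc2ccc(Cl)cc2Cl)cn3C2CC2)CC1` gives > 20000 nM, again a limit of the assay. Compound 3 `CCOC(=O)C1CCN(c2cc3c(cc2F)c(=O)c(C(=O)NCc2ccc(Cl)cc2Cl)cn3CC)CC1` gives 10000 nM in this assay. Among the compounds with values here, that is the only number in the set, as two of the three values sit at the limit of > 20000 nM in this assay, at which 2 of the 3 values shown sit. Within the data shown here, no two measured compounds differ in one place, so no measured step is available, and compound 3 stands as the one point of the set with a number while the remaining two sit at the limit.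

Compound 4 `CCOC(=O)N1CCN(c2cc3c(cc2F)c(=O)c(C(=O)NCc2ccc(Cl)cc2Cl)cn3CC)CC1` has not yet been measured. It differs from compound 3 by 4-(ethoxycarbonyl)piperazin-1-yl in place of 4-(ethoxycarbonyl)piperidin-1-yl on an aromatic carbon. Among the measured compounds shown here, with no measured step to lean on, the expectation for this assay rests on the size of the change alone: an exchange of a single ring atom within a group otherwise unchanged. The expected step is a 1.5-fold higher number from compound 3 to compound 4 (0.18 log units; within the scatter), not beyond the usual scatter in either direction, with a slight lean toward more compound being tolerated. Compound 4 is estimated at 15000 nM, with a range from 5000 nM to 40000 nM, and a reading at the limit remains possible.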

Compound 4, half-maximal cytotoxic concentration: > 20000 nM
Compound 4: no number, only a limit; the forecaster's own chance of this, stated with the estimate: 40%; at least 1.3-fold (0.12 log units) between middle value and limit.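

In this assay, within the data shown here, 4-(ethoxycarbonyl)piperazin-1-yl in place of 4-(ethoxycarbonyl)piperidin-1-yl on the aromatic carbon ortho to a fluoro group gives the first step: an at least 2.0-fold higher number from compound 3 to compound 4 (0.30 log units; that floor lies within the scatter). Among these compounds, the reading of compound 4 is a limit of the assay and not a number, so this exchange of a ring carbon for a ring nitrogen, with the heavy-atom count unchanged, gives no sign of less compound being tolerated, although the floor of the step does not clear the scatter. Among the compounds shown here, the earlier compounds left compound 3 as the only number with no step to it, and the change now adds one more compound to those at the top of the range: the limit of > 20000 nM in this assay, at which 3 of the 4 values shown sit.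

On these data alone, how far the true value of compound 4 lies past the limit stays unknown, and with it the real size of the step. Also open, as far as these compounds go, is whether a free secondary amine on the piperazin-1-yl ring, or a carboxylic acid in place of the ethyl ester, would keep readings at the limit or bring them down to a number.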